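Notes on the step from compound 2 to compound 3

The source may hold more compounds than are shown below. What is called first, only, known or untested is meant among the compounds shown, and "the series" means these compounds.

Measured compounds:
compound 1: `COc1cc2cc(Oc3ccc(NC(=O)Nc4ccccc4)cc3)c(C)nc2cc1OC` — 70.3%
compound 2: `COc1cc2cc(Oc3ccc(NC(=O)Nc4ccc(C(F)(F)F)cc4)cc3)c(C)nc2cc1OC` — 64.4%

All numbers come from a functional assay on KM12 cells (Homo sapiens) for inhibition, read by sulforhodamine B assay, with a stated time of 48 h, tested at 10 uM; a higher number here means a weaker effect of the compound at the concentration tested, a lower number a stronger effect. In this assay compound 1 gives 70.3% and compound 2 gives 64.4%. The two values lie within the scatter of each other, so on the numbers shown compound 2 is not separated from compound 1. For the measured compounds named here, the only measured step, a number 5.9 percentage points lower from compound 1 to compound 2 (within the scatter), is also within the scatter.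

Compound 3 is `COc1cc2cc(Oc3ccc(NC(=O)Nc4cccc(C(F)(F)F)c4)cc3)c(C)nc2cc1OC`. It differs from compound 2 as follows: 3-(trifluoromethyl)phenyl in place of 4-(trifluoromethyl)phenyl on an amide-type nitrogen. The two have the same atoms, joined differently; 4-(trifluoromethyl)phenyl leaves and 3-(trifluoromethyl)phenyl enters on an amide-type nitrogen whose other neighbour is a carbonyl carbon.

Going by the values given here, no measured pair shows what this change does. The step from compound 1 to compound 2 bears only loosely on it, as it added the trifluoromethyl rather than moving it, and it was within the scatter. The expected step is therefore none beyond the scatter: a number 0.6 percentage points higher from compound 2 to compound 3 (within the scatter). Compound 3 is estimated at 65%, with a range from 50% to 80%.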

Compound 3, a percentage reported as activity, at one concentration (the size of the read-out at that concentration, not a potency): -10.2%
Compound 3: the middle estimate sits 75.2 percentage points above what was measured, outside the stated range (below it).
By their numbers in this assay, from the lowest: compound 3; then compounds 2 and 1 (each within the scatter of the next).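

In this assay, 3-(trifluoromethyl)phenyl in place of 4-(trifluoromethyl)phenyl on the amide-type nitrogen gives a number 74.6 percentage points lower from compound 2 to compound 3 (beyond the scatter), so with the same atoms, where the trifluoromethyl sits on this aromatic ring separates these two compounds sharply, which the earlier pair could not show. Set against the phenyl of compound 1, trifluoromethyl in place of hydrogen gives a number 80.5 percentage points lower from compound 1 to compound 3 (beyond the scatter), whereas the earlier change gave only a number 5.9 percentage points lower from compound 1 to compound 2 (within the scatter); among these three compounds, adding the group therefore has a large effect on the read-out only in the 3-(trifluoromethyl)phenyl form. No measurement available here accounts for the size of this difference.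

Still open, as far as these compounds go, is whether the large step belongs to trifluoromethyl itself, or whether a chlorine, a methoxy group or a carboxylic acid in the place held by the trifluoromethyl of compound 3 would give a similar read-out. The read-out is also taken at a single concentration in one cell line, so it gives neither a potency for compound 3 nor any indication of how the step would carry over to other cells.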